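Aryl amide in place of cyanomethyl amide on shared core

The source may hold more compounds than are shown below. What is called first, only, known or untested is meant among the compounds shown, and "the series" means these compounds.

The measured compounds:
compound 1, `CCn1c(C(=O)NCC#N)ccc1C(CC)(CC)c1ccc(OCCC(O)(CC)CC)c(C)c1`, in an assay on cells for agonist activity at vitamin D3 receptor (Homo sapiens), with a stated time of 96 h (on this read-out higher numbers stand for an effect only at larger amounts of compound and lower numbers for an effect already at smaller amounts), compound 1 gives 1080 nM.
compound 2, `C#CC(C)OC(=O)c1ccc(C(CC)(CC)c2ccc(OCCC(O)(CC)CC)c(C)c2)n1CC`, in this assay compound 2 gives 2650 nM.
compound 3, `CCn1c(C(=O)Nc2ccc(OC(F)(F)F)cc2)ccc1C(CC)(CC)c1ccc(OCCC(O)(CC)CC)c(C)c1`, in this assay compound 3 gives > 10000 nM, which is a limit of the assay (the limit of > 10000 nM in this assay, at which 1 of the 3 values shown sits).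

Compound 1 stands lowest of the two numbers shown; its nearest neighbour is compound 2, with a 2.5-fold higher number from compound 1 to compound 2 (0.39 log units; beyond the scatter). Compound 4, `CCn1c(C(=O)Nc2cccc(C(F)(F)F)c2)ccc1C(CC)(CC)c1ccc(OCCC(O)(CC)CC)c(C)c1`, is not yet measured. It differs from compound 1 in one place: 3-(trifluoromethyl)phenyl in place of cyanomethyl on an amide-type nitrogen.

The step that bears most closely on this change is an at least 9.2-fold higher number from compound 1 to compound 3 (0.96 log units; beyond the scatter), where an aryl amide likewise replaces the cyanomethyl amide, though there the aryl group carries trifluoromethoxy rather than trifluoromethyl. The step of an at least 3.7-fold higher number from compound 2 to compound 3 (0.57 log units; beyond the scatter) points the same way, an aryl amide giving a number beyond the limit. Both known changes away from compound 1 at this position raised the number, and the aryl case did so most. Compound 4 is therefore expected to show a clearly higher number in this assay than compound 1, of the order a 7.4-fold higher number from compound 1 to compound 4 (0.87 log units; beyond the scatter), with a real chance that only a limit is reported. The estimate for compound 4 in this assay is 8000 nM, expected between 2500 nM and 30000 nM.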

Compound 4, half-maximal effective concentration: 5900 nM
Compound 4: middle estimate off by 1.4-fold (0.13 log units), on the high side; the measured number falls inside the stated range.
By their numbers in this assay, from the lowest: compound 1; then compound 2; then compound 4. At a limit, above all of these: compound 3.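

In this assay, the cost of replacing cyanomethyl with 3-(trifluoromethyl)phenyl on the amide-type nitrogen can now be sized: a 5.5-fold higher number from compound 1 to compound 4 (0.74 log units; beyond the scatter). The same aryl amide also reads against the other replacement on the carbonyl carbon, with a 2.2-fold higher number from compound 2 to compound 4 (0.35 log units; beyond the scatter), so among the compounds with numbers, the (cyanomethyl)amino of compound 1 gives the lowest, followed by the (1-methylprop-2-yn-1-yl)oxy of compound 2 and the (3-(trifluoromethyl)phenyl)amino of compound 4. The value of compound 3 is a limit: the limit of > 10000 nM in this assay, at which 1 of the 4 values shown sits. Measured against that limit, 3-(trifluoromethyl)phenyl in place of 4-(trifluoromethoxy)phenyl on the amide-type nitrogen gives an at least 1.6-fold lower number from compound 3 to compound 4 (0.22 log units; that floor lies within the scatter), so this step alone does not set the two aryl amides apart.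

From the compounds shown here alone, it remains open whether a plain phenyl on that nitrogen would lie nearer compound 1 or compound 4, so the contributions of the aromatic ring and of the trifluoromethyl cannot be separated. Also open, going by these compounds, is how a carboxylic acid or a longer chain ending in a nitrile would read at this position, and whether any replacement there can give a lower number than compound 1.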